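The compounds below may be only part of what the source reports. "The series", "measured", "known", "first", "only" and "open" are said of these compounds alone.

Measured so far:
compound 1, `Cc1cc(C)cc(NC(=O)COc2cc(C)nc3ccc(F)cc23)c1`: 5.79
compound 2, `COc1ccc2nc(C)cc(OCC(=O)Nc3cc(C)ccc3C)c2c1`: 5.05

In a physicochemical assay for lipophilicity, read by HPLC, in phosphate buffer, measured as chromatographic lipophilicity, at pH 7.4 (a lower number here means a more polar compound, a higher number a more lipophilic compound), compound 2 stands lowest of the two numbers, with compound 1 as its nearest neighbour at 5.79, a gap beyond the scatter. Compound 3, `COc1ccc2nc(C)cc(OCC(=O)Nc3nccs3)c2c1`, is not yet measured. It differs from compound 2 as follows: 1,3-thiazol-2-yl in place of 2,5-dimethylphenyl on an amide-type nitrogen. For the measured compounds named here, no step between measured compounds covers a change of this kind, so the size rests on expectation alone. The expected step, downward and well beyond the scatter, is a number 1.75 log units lower from compound 2 to compound 3 (beyond the scatter). For compound 3 in this assay the estimated value is 3.3, in a range from 2.6 to 4.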

Compound 3, distribution coefficient: 3.2
Estimate against measurement, compound 3: 0.10 log units above, within the range that was stated.
By their numbers in this assay, from the lowest: compound 3; then compound 2; then compound 1.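

In this assay, 1,3-thiazol-2-yl in place of 2,5-dimethylphenyl on an amide-type nitrogen gives a number 1.85 log units lower from compound 2 to compound 3 (beyond the scatter), the first step read at this position. With the rest of the structure unchanged, this single exchange moves the number well beyond the scatter. Nothing available explains the size of the step.

Still open, going by these compounds, is whether a pyridin-2-yl group on the same nitrogen would fall nearer compound 2 or compound 3. Also open, on these data alone, is whether the same exchange on the core of compound 1 gives a step of similar size.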